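This account rests on a few compounds, and the source may have more. Where it says the series, first, only, none or still open, it means among the compounds named here.

Measured compounds:
Compound 1, `COc1nccc(-c2ccc(S(=O)(=O)N[C@H]3CCN(Cc4cccc(C(=N)N)c4)C3=O)s2)n1`. In an assay on isolated protein for inhibition of Trypsin II (Bos taurus) (on this read-out higher numbers stand for weaker inhibition and lower numbers for stronger inhibition), compound 1 gives > 2900 nM, which is a limit of the assay and not a number, (the limit of > 2900 nM in this assay, at which 1 of the 2 values shown sits).
Compound 2, `N=C(N)c1cccc(CN2CC[C@H](NS(=O)(=O)c3ccc(-c4ccon4)s3)C2=O)c1`. In this assay compound 2 gives 1900 nM.

For the measured compounds named here, compound 2 therefore stands as the only compound with an actual number in this assay; the other entry is a limit. Going by the values given here, the single measured step, an at least 1.5-fold lower number from compound 1 to compound 2 (0.18 log units; that floor lies within the scatter), exchanges 2-methoxypyrimidin-4-yl for 1,2-oxazol-3-yl on an aromatic carbon, and its floor lies within the usual scatter, so it shows no clear movement.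

Compound 3, `N=C(N)c1ccc(N)c(CN2CC[C@H](NS(=O)(=O)c3ccc(-c4ccon4)s3)C2=O)c1`, differs from compound 2 by amino in place of hydrogen on an aromatic carbon. Among the compounds with values here, no measured step touches this position or this kind of change; the one step available concerns a different group and is itself within the scatter, so it gives neither a size nor a direction to lean on. Compound 3 is accordingly expected to show no step beyond the scatter, a 1.2-fold lower number from compound 2 to compound 3 (0.07 log units; within the scatter). The estimate for compound 3 in this assay is 1600 nM, with a range from 500 nM to 5000 nM.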

Compound 3, inhibition constant: 1700 nM
Compound 3: middle estimate off by 1.1-fold (0.03 log units), on the low side; the measured number falls inside the stated range.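

In this assay, amino in place of hydrogen on the six-membered aromatic ring of carbon only, ortho to a large group and para to a group of 3 heavy atoms, gives a 1.1-fold lower number from compound 2 to compound 3 (0.05 log units; within the scatter), so this first read of that position shows no clear movement. The exchange of hydrogen for amino at this place therefore yields a number that cannot be told apart from that of the parent compound, and compound 3 joins compound 2 as a compound with an actual number rather than a limit. Nothing shown offers a reason for this outcome.

For the compounds shown here, it remains open whether a larger group at the same place, such as an acetamide, a dimethylamino group or a methoxy group, would move the number beyond the scatter, as amino is the only group there so far. As far as these compounds go, it also remains open whether amino would behave the same way with 2-methoxypyrimidin-4-yl on the shared core in place of 1,2-oxazol-3-yl.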